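A few compounds are considered here, and "the series" means these few. Any claim that something is new, unique, unknown or untested is made for them only; others in the source may bear on it.

Compound 1 `O=S(=O)(Nc1ccc2oc(-c3ccc(NS(=O)(=O)c4cccc5nonc45)cc3)nc2c1)c1ccc(Cl)s1` gives 13000 nM
Compound 2 `O=S(=O)(Nc1ccc(-c2nc3cc(NS(=O)(=O)c4ccccc4)ccc3o2)cc1)c1ccccc1` gives 80000 nM
Compound 3 `O=S(=O)(Nc1ccc(-c2nc3ccccc3o2)cc1)c1cccc(F)c1` gives 71000 nM

In an assay on cells for inhibition of HSP60/HSP10 (Homo sapiens), with a stated time of 60 min (on this read-out higher numbers stand for weaker inhibition and lower numbers for stronger inhibition), compound 3 gives 71000 nM, the second highest of the three numbers. Compound 2 sits within the scatter of it, so the two cannot be told apart on this read-out, while compound 1 stands beyond the scatter with the lowest number of the three. Compound 4 `CS(=O)(=O)Nc1ccc(-c2nc3ccccc3o2)cc1` differs from compound 3 in one place: methyl in place of 3-fluorophenyl on a sulfonyl sulfur. Within the data shown here, no pair of measured compounds shows this change, so no measured step can guide the expectation. The expected step from compound 3 to compound 4 is a modest move toward a higher number, a 1.5-fold higher number from compound 3 to compound 4 (0.19 log units; within the scatter), possibly not beyond the scatter. Compound 4 is therefore estimated at 110000 nM, within a range of 45000 nM to 300000 nM.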

Compound 4, half-maximal inhibitory concentration: > 100000 nM
Compound 4 was reported as a limit (the forecaster's own chance of this, stated with the estimate: 30%); the middle value is on the limit's open side.
By their numbers in this assay, from the lowest: compound 1; then compounds 3 and 2 (each within the scatter of the next). At a limit, above all of these: compound 4.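

Replacing 3-fluorophenyl with methyl on a sulfonyl sulfur gives an at least 1.4-fold higher number from compound 3 to compound 4 (0.14 log units; that floor lies within the scatter). The value of compound 4 is a limit of the assay and not a number: the limit of > 100000 nM in this assay, at which 1 of the 4 values shown sits. This first measured step at this position shows that compound 4, with methyl on the sulfonyl sulfur, yields no number on this read-out, but the true size of the step cannot be read, and its floor alone does not separate compound 4 from compound 3. From the compounds shown here alone, whether a butyl chain or an amine on this sulfonyl sulfur would return a number in this assay stays open.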